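The compounds below may be only part of what the source reports. "The series", "measured", "known", "first", "only" and "open" are said of these compounds alone.

In a functional assay (trachea) with Cavia porcellus as the target (a lower number here means that less compound is needed, a higher number that more compound is needed for the effect), compound 3 `CCCn1c(=O)n(CCC(=O)O)c(=O)c2[nH]cnc21` gives 21200 nM, the highest of the three numbers measured. Compound 1 `CCCn1c(=O)n(CC)c(=O)c2[nH]cnc21` gives 1300 nM and compound 2 `C=CCCn1c(=O)c2[nH]cnc2n(CCC)c1=O` gives 200 nM; the steps are a 16-fold higher number from compound 1 to compound 3 (1.21 log units; beyond the scatter) and a 110-fold higher number from compound 2 to compound 3 (2.03 log units; beyond the scatter), while a 6.5-fold lower number from compound 1 to compound 2 (0.81 log units; beyond the scatter). Compound 4 `CCCn1c(=O)n(CCCOC)c(=O)c2[nH]cnc21` differs from compound 3 by methoxymethyl in place of carboxy on a saturated chain carbon, two bonds along the chain from an aromatic nitrogen. Carboxy is the group that sets compound 3 apart from the other two, so its removal should undo much of a 16-fold higher number from compound 1 to compound 3 (1.21 log units; beyond the scatter); methoxymethyl is neither hydrogen nor vinyl, so the further gain seen in a 6.5-fold lower number from compound 1 to compound 2 (0.81 log units; beyond the scatter) is not assumed. Compound 4 is therefore expected to show a 24-fold lower number from compound 3 to compound 4 (1.37 log units; beyond the scatter), a large step toward a lower number. The estimate for compound 4 is 900 nM, with a range from 250 nM to 3500 nM.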

Compound 4, half-maximal effective concentration: 2900 nM
Estimate against measurement, compound 4: 3.2-fold (0.51 log units) below; the measured number falls inside the stated range.
By their numbers in this assay, from the lowest: compound 2; then compound 1; then compound 4; then compound 3.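

In this assay, methoxymethyl in place of carboxy at this position lowers the number, with a 7.3-fold lower number from compound 3 to compound 4 (0.86 log units; beyond the scatter), but this recovers only part of the ground, since methoxymethyl still gives a 2.2-fold higher number from compound 1 to compound 4 (0.35 log units; beyond the scatter). The position therefore responds to more than the loss of carboxy: the chain end also counts, as a 15-fold higher number from compound 2 to compound 4 (1.16 log units; beyond the scatter) shows. Nothing at hand explains these steps. Going by these compounds, whether an amine or a longer plain alkyl chain at this place would track vinyl or methoxymethyl remains open.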